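The source may hold more compounds than are shown below. What is called first, only, known or untested is meant among the compounds shown, and "the series" means these compounds.

Compound 1 (`CCOC(=O)C1=C(C)NC(=S)NC1c1ccc(O)cc1`) gives > 250 ug/mL in a functional assay on HT-29 cells (Homo sapiens) for inhibition, read by sulforhodamine B assay, with a stated time of 48 h (on this read-out lower numbers stand for stronger inhibition of growth and higher numbers for weaker inhibition of growth), and this is a limit, not a number. Compound 2 (`CCOC(=O)C1=C(C)NC(=S)NC1c1ccc(O)c(OC)c1`) gives 34.9 ug/mL in this assay. Among the measured compounds shown here, the one measured step, methoxy in place of hydrogen on an aromatic carbon, is an at least 7.1-fold lower number from compound 1 to compound 2 (0.85 log units; beyond the scatter). Compound 3 (`CCOC(=O)C1=C(C)NC(=S)NC1c1ccc(OC)cc1`) instead carries methyl in place of hydrogen on an oxygen on an aromatic ring, hydroxy to methoxy. The step to compound 2 bears only loosely, as there the hydroxy remains, so a smaller drop in this assay is expected. The expected step is an at least 2.5-fold lower number from compound 1 to compound 3 (0.39 log units; beyond the scatter). For compound 3 the estimate is 100 ug/mL, with an expected range of 30 ug/mL to 250 ug/mL.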

Compound 3, concentration for 50% growth inhibition: 30.6 ug/mL
Compound 3: the middle estimate sits 3.3-fold (0.51 log units) above what was measured, within the range that was stated.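

On this oxygen on an aromatic ring, the free hydroxy of compound 1 is not needed for growth inhibition: methyl in place of hydrogen gives an at least 8.1-fold lower number from compound 1 to compound 3 (0.91 log units; beyond the scatter) in this assay. This change alone, with no second group added to the ring, moves the number beyond the scatter. The starting point for compound 1 is a limit, not a number: the limit of > 250 ug/mL in this assay, at which 1 of the 3 values shown sits.

Still open, going by these compounds, is how a longer chain on this oxygen, such as ethoxy, would read in this assay. On these data alone, an amine in place of the hydroxy is also open.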